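A few compounds are considered here, and "the series" means these few. Any claim that something is new, unique, unknown or untested is made for them only; others in the source may bear on it.

Measured compounds:
Compound 1 `COc1ccc(C2CC(c3ccccc3)=NN2C2=NC(=O)/C(=C3\C(=O)Nc4ccc(Br)cc43)S2)cc1` gives 390 nM in a functional assay on cells (Cancer cell lines, Homo sapiens) for cytotoxicity, read by sulforhodamine B assay, with a stated time of 48 h; on this read-out higher numbers stand for weaker inhibition of growth and lower numbers for stronger inhibition of growth.
Compound 2 `COc1ccc(C2=NN(C3=NC(=O)/C(=C4\C(=O)Nc5ccc(Br)cc54)S3)C(c3ccc(OC)cc3)C2)cc1` gives 405 nM in this assay.
Compound 3 `COc1ccc(C2CC(c3ccc4ccccc4c3)=NN2C2=NC(=O)/C(=C3\C(=O)Nc4ccccc43)S2)cc1` gives 12600 nM in this assay.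

Compound 3 stands at the highest number of the three, far from compound 1 and compound 2, which lie close together: a 1.0-fold higher number from compound 1 to compound 2 (0.02 log units; within the scatter). Compound 4 `COc1ccc(C2CC(c3ccc4ccccc4c3)=NN2C2=NC(=O)/C(=C3\C(=O)Nc4ccc(Br)cc43)S2)cc1` is compound 3 with one change: bromo in place of hydrogen on an aromatic carbon. Compound 1 and compound 2 both carry this bromo, yet neither differs from compound 3 by the bromo alone, since compound 3 also bears a different aryl group on its shared core. Among the compounds with values here, no measured step therefore isolates the effect of adding the bromo, and the large gap between compound 3 and the other two cannot be assigned to either change on its own. Within the data shown here, the only measured step, from compound 1 to compound 2, concerns a methoxy and says nothing about bromo. Given that both compounds carrying the bromo sit at low numbers, a move toward stronger growth inhibition is expected for compound 4, and the expected step is a 3.2-fold lower number from compound 3 to compound 4 (0.50 log units; beyond the scatter). Compound 4 is expected to give about 4000 nM in this assay, within a range from 1000 nM to 16000 nM.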

Compound 4, concentration for total growth inhibition: 210 nM
Compound 4: the middle estimate sits 19-fold (1.28 log units) above what was measured; measured number below the stated range.
By their numbers in this assay, from the lowest: compounds 4, 1 and 2 (each within the scatter of the next); then compound 3.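

In this assay, within the data shown here, the change of hydrogen to bromo on an aromatic carbon of the fused two-ring system now stands alone, and it gives a 60-fold lower number from compound 3 to compound 4 (1.78 log units; beyond the scatter); the earlier compounds could not separate this step from a change of aryl group. Once the bromo is present, the aryl group on the carbon with a double bond to nitrogen makes no clear difference: naphthalen-2-yl in place of phenyl gives a 1.9-fold lower number from compound 1 to compound 4 (0.27 log units; within the scatter), and naphthalen-2-yl in place of 4-methoxyphenyl gives a 1.9-fold lower number from compound 2 to compound 4 (0.29 log units; within the scatter), both within the scatter. So the weak value of compound 3 goes with the missing bromo in this pair, although nothing available here explains how a single bromine atom produces a step of this size.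

Going by these compounds, it remains open whether chloro, a nitrile or an amine on this same aromatic carbon would behave like bromo or like hydrogen. On these data alone, it is also open whether hydrogen in place of bromo would bring as large a step with phenyl or 4-methoxyphenyl on the carbon with a double bond to nitrogen as it does with naphthalen-2-yl.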